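Cyclohexyl in Place of Pyridazinyl on the Alkyne

The source may report more compounds than this note shows. Statements on the series, on what has been measured and on what is new or still open speak of the compounds shown alone.

Of the compounds shown here, two sharing one core have so far been tested in an assay on CHO cells for displacement of a labelled ligand from adenosine receptor A1 (Homo sapiens), read by scintillation counting, with a stated time of 60 min, tested at 10 uM; on this read-out lower numbers stand for less inhibition and higher numbers for more inhibition at the one concentration tested (going by the name of the read-out). Compound 1 `CNC(=O)[C@@]12C[C@@H]1[C@@H](n1cnc3c(NC)nc(C#Cc4ccccc4)nc31)[C@H](O)[C@@H]2O` gives 18% in this assay. Compound 2 `CNC(=O)[C@@]12C[C@@H]1[C@@H](n1cnc3c(NC)nc(C#Cc4cccnn4)nc31)[C@H](O)[C@@H]2O` gives 11% in this assay. For the measured compounds named here, the single measured step, a number 7 percentage points lower from compound 1 to compound 2 (within the scatter), puts pyridazin-3-yl in place of phenyl on a triple-bonded carbon and lies within the scatter, so neither compound can be called the stronger. Of the two numbers shown, that of compound 2 is the smaller as written, with compound 1 as its only neighbour and the gap within the scatter.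

Compound 3 `CNC(=O)[C@@]12C[C@@H]1[C@@H](n1cnc3c(NC)nc(C#CC4CCCCC4)nc31)[C@H](O)[C@@H]2O` is not yet measured. It differs from compound 2 as follows: cyclohexyl in place of pyridazin-3-yl on a triple-bonded carbon. Going by the values given here, the only step that bears on this change is a number 7 percentage points lower from compound 1 to compound 2 (within the scatter), which swapped one aromatic ring for another at the same triple-bonded carbon and stayed within the scatter; there is no measured step to a non-aromatic ring. On that basis the account expects no step beyond the scatter, a number 4 percentage points higher from compound 2 to compound 3 (within the scatter), in no certain direction. Compound 3 is estimated at 15% in this assay, with a range from 0% to 35%.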

Compound 3, a percentage reported as inhibition, at one concentration (the size of the read-out at that concentration, not a potency): 15%
Compound 3: middle estimate and measured number agree at the digits printed, within the range that was stated.
By their numbers in this assay, from the lowest: compounds 2, 3 and 1 (each within the scatter of the next).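

A non-aromatic ring of carbon only on the triple-bonded carbon does not shift this assay beyond the scatter: cyclohexyl in place of pyridazin-3-yl gives a number 4 percentage points higher from compound 2 to compound 3 (within the scatter) and cyclohexyl in place of phenyl gives a number 3 percentage points lower from compound 1 to compound 3 (within the scatter). The earlier step covered only one aromatic ring in place of another, whereas these two steps extend the same reading to the loss of aromaticity and, in the step from pyridazin-3-yl, to a ring with no hydrogen-bond acceptors, so among these three six-membered rings the number shows no dependence on the kind of ring that can be told from the scatter. No measurement at hand accounts for how close these numbers lie.

From the compounds shown here alone, all three compounds carry a six-membered ring at this place, so it stays open whether a group of another kind there, such as a primary amine, a carboxylic acid or a straight hexyl chain, would move the number beyond the scatter. The read-out is also a size at one concentration, which leaves open how the three compounds would compare as potencies.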